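Swapping cyclohexyl for dichlorophenyl on a shared thione core

The compounds below may be only part of what the source reports. "The series", "measured", "known", "first", "only" and "open" are said of these compounds alone.

Of the compounds shown here, two built on the same core have so far been measured in a functional assay, with a stated time of 6 min; on this read-out lower numbers stand for stronger inhibition and higher numbers for weaker inhibition. Compound 1 `S=c1oc(-c2ccc3c(c2)OCCO3)nn1CNC1CCCCC1` gives 18400 nM in this assay. Compound 2 `FC(F)(F)c1cc(NCn2nc(-c3ccc4c(c3)OCCO4)oc2=S)cc(C(F)(F)F)c1` gives 9320 nM in this assay. Compound 1 holds the highest of the two numbers; its nearest neighbour, compound 2, sits lower, but the gap lies within the scatter, so the two are not told apart.

Compound 3 `S=c1oc(-c2ccc3c(c2)OCCO3)nn1CNc1ccc(Cl)cc1Cl` has not yet been measured. Relative to compound 1 it carries 2,4-dichlorophenyl in place of cyclohexyl on an amine nitrogen. Among the compounds with values here, no step between measured compounds isolates this particular change, so any expectation rests on the two values alone. Compound 2, which also bears an aromatic group on that amine nitrogen, gives 9320 nM in this assay. The step of a 1.9-fold lower number from compound 1 to compound 3 (0.29 log units; within the scatter) is therefore expected to be small, toward a lower number, and not clearly beyond the scatter. Compound 3 is estimated at 9500 nM in this assay, with a range expected to run from 3500 nM to 26000 nM.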

Compound 3, half-maximal inhibitory concentration: 8710 nM
Compound 3: middle estimate off by 1.1-fold (0.04 log units), on the high side; the measured number falls inside the stated range.
By their numbers in this assay, from the lowest: compounds 3, 2 and 1 (each within the scatter of the next, the first and the last beyond it).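

In this assay, within the data shown here, replacing cyclohexyl with 2,4-dichlorophenyl on the amine nitrogen now has a step of its own, a 2.1-fold lower number from compound 1 to compound 3 (0.32 log units; beyond the scatter) and this modest shift is the first difference to clear the scatter. The earlier pair could not be told apart, whereas this one shows that the number at this position responds to the change from a saturated ring of carbon to a chlorinated aromatic ring, at least for this single pair. Among the aromatic groups, compound 3 at 8710 nM and compound 2 at 9320 nM lie within the scatter of each other, so the two different sets of substituents on the ring cannot be separated on these numbers.

From the compounds shown here alone, it remains open whether an unsubstituted phenyl ring, a ring with only one chlorine, or a ring bearing a carboxylic acid or an amine would give a number like those of compound 2 and compound 3 or move it further. The data shown offer no measurement that explains why the number shifts with this change.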